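The source may hold more compounds than are shown below. What is called first, only, known or untested is meant among the compounds shown, and "the series" means these compounds.

Compound 1 `Nc1ncnc2c1c(-c1cnc3[nH]ccc3c1)nn2CCCCCCCCC(=O)NO` gives 7470 nM
Compound 2 `Nc1nc2cc(-c3nn(CCCC(=O)NO)c4ncnc(N)c34)ccc2o1` gives > 150000 nM (a limit)
Compound 3 `Nc1nc2cc(-c3nn(CCC(=O)NO)c4ncnc(N)c34)ccc2o1` gives > 150000 nM (a limit)

In a functional assay on HeLa cells (Homo sapiens) for inhibition, read by MTT assay, with a stated time of 72 h (a higher number here means a weaker inhibitor, a lower number a stronger inhibitor), compound 1 gives 7470 nM, the only true number among these compounds. The other two values are limits. Compound 4 `Nc1ncnc2c1c(-c1cnc3[nH]ccc3c1)nn2CCCCCCC(=O)NO` differs from compound 1 by hydroxycarbamoyl in place of 2-(hydroxycarbamoyl)ethyl on a saturated chain carbon, six bonds along the chain from an aromatic nitrogen, which is hydroxycarbamoyl in place of 2-(hydroxycarbamoyl)ethyl on a saturated chain carbon, six bonds along the chain from an aromatic nitrogen. Within the data shown here, the one measured step, a step that the two limits leave unreadable from compound 2 to compound 3, also shortens a chain, yet it rests on the limit of > 150000 nM in this assay, at which 2 of the 3 values shown sit, and offers no size to carry over. Only a modest loss of inhibition is therefore expected in this assay, and the expected change is a 1.3-fold higher number from compound 1 to compound 4 (0.13 log units; within the scatter). Compound 4 is estimated at 10000 nM, with an expected range of 3000 nM to 40000 nM.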

Compound 4, half-maximal inhibitory concentration: 22000 nM
The estimate for compound 4 lay 2.2-fold (0.34 log units) below the measured number, and the stated range covers the measured number.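

In this assay, shortening the chain now has a readable size: a 2.9-fold higher number from compound 1 to compound 4 (0.47 log units; beyond the scatter). On the shared core, at this place on a saturated chain carbon, six bonds along the chain from an aromatic nitrogen, replacing 2-(hydroxycarbamoyl)ethyl with hydroxycarbamoyl therefore weakens inhibition beyond the scatter. The other chain step cannot be read, as compound 2 and compound 3 each give only a limit: the limit of > 150000 nM in this assay, at which 2 of the 4 values shown sit.

From the compounds shown here alone, whether a longer chain would strengthen inhibition remains open. So does whether a carboxylic acid or an amine at the chain end would retain any inhibition.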